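Swapping a nitrile for a phenyl ring on the ester

This account rests on a few compounds, and the source may have more. Where it says the series, first, only, none or still open, it means among the compounds named here.

Of the compounds shown here, three built on one shared core have been measured in an ADME assay on a cell-free system (plasma, Homo sapiens) for metabolic stability, with Plasma (Rattus norvegicus) as the target, read by HPLC, at pH 7.4; on this read-out higher numbers stand for a longer-lived compound and lower numbers for a shorter-lived compound. Compound 1 `CCC(=O)O[C@@H]1CO[C@H]2[C@@H]1OC[C@@H]2OC(=O)c1ccccc1OC(C)=O` gives 0.0608 h. Compound 2 `CC(=O)Oc1ccccc1C(=O)O[C@H]1CO[C@H]2[C@@H]1OC[C@H]2OC(=O)c1cccc(C)c1` gives 0.165 h. Compound 3 `CC(=O)Oc1ccccc1C(=O)O[C@H]1CO[C@H]2[C@@H]1OC[C@H]2OC(=O)c1ccc(C#N)cc1` gives 0.0888 h, the second highest of the three numbers, though its gaps to compound 1 and to compound 2 both lie within the scatter, so no order among the three can be read from them. Among the compounds with values here, the only step beyond the scatter is a 2.7-fold higher number from compound 1 to compound 2 (0.43 log units; beyond the scatter). The steps of a 1.5-fold higher number from compound 1 to compound 3 (0.16 log units; within the scatter) and a 1.9-fold lower number from compound 2 to compound 3 (0.27 log units; within the scatter) stay within the scatter.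

Compound 4 `CC(=O)Oc1ccccc1C(=O)O[C@H]1CO[C@H]2[C@@H]1OC[C@H]2OC(=O)c1ccc(-c2ccccc2)cc1` differs from compound 3 in one place: phenyl in place of cyano on an aromatic carbon. Within the data shown here, no measured step exchanges one group for another on this aromatic ring, so the nearest guide is the exchange of substituent on the aromatic ester between compound 2 and compound 3, which remained within the scatter. The aromatic esters of compound 2 and compound 3 both sit within the scatter of each other, and nothing here separates one aromatic substituent from another. Compound 4 is therefore expected to move little, with an estimated step of a 1.4-fold higher number from compound 3 to compound 4 (0.13 log units; within the scatter). The estimate for compound 4 in this assay is 0.12 h, within a range from 0.05 h to 0.3 h.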

Compound 4, half-life: > 0.333 h
Compound 4: a limit, no number (the forecaster's own chance of this, stated with the estimate: 5%); at least 2.7-fold (0.44 log units) between middle value and limit.
By their numbers in this assay, from the lowest: compounds 1, 3 and 2 (each within the scatter of the next, the first and the last beyond it). At a limit, above all of these: compound 4.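

The value for compound 4 is a limit of this assay and not a number: the limit of > 0.333 h in this assay, at which 1 of the 4 values shown sits. Even as a limit, it shows that this place on the aromatic ester responds to the exchange of cyano for phenyl, which gives an at least 3.7-fold higher number from compound 3 to compound 4 (0.57 log units; beyond the scatter), and the gap to the ethyl ester of compound 1 is also clear, at an at least 5.4-fold higher number from compound 1 to compound 4 (0.73 log units; beyond the scatter). The earlier exchange on the aromatic ester, a 1.9-fold lower number from compound 2 to compound 3 (0.27 log units; within the scatter), gave no such signal, although the remaining step, an at least 2.0-fold higher number from compound 2 to compound 4 (0.30 log units; that floor lies within the scatter), does not separate the 4-phenylphenyl ester from the 3-methylphenyl ester.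

From the compounds shown here alone, how far the true half-life of compound 4 lies past its limit remains open, so the full size of all these steps is unknown. It is also open how an amine, a carboxylic acid or a saturated cyclohexyl ring would behave at this place, so the compounds shown cannot tell whether the longer half-life goes with the aromatic ring itself or simply with a larger group.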